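Ketoamide series: neopentyl extension of compound 1

This account rests on a few compounds, and the source may have more. Where it says the series, first, only, none or still open, it means among the compounds named here.

compound 1, `CCCC[C@H](NC(=O)OC(C(C)C)C(C)C)C(=O)C(=O)Nc1ccnn1C`: 1700 nM
compound 2, `CCCC[C@H](NC(=O)OC(C(C)C)C(C)C)C(=O)C(=O)Nc1ccn(C)n1`: 11 nM

In an assay on isolated protein for inhibition of cathepsin K (Rattus norvegicus) (a lower number here means a stronger inhibitor, a higher number a weaker inhibitor), compound 1 gives 1700 nM, the higher of the two numbers; compound 2 gives 11 nM. Among the measured compounds shown here, the only measured step, a 150-fold lower number from compound 1 to compound 2 (2.19 log units; beyond the scatter), swaps one ring isomer for the other and leaves the methyl on the aromatic nitrogen untouched. Compound 3, `CCCC[C@H](NC(=O)OC(C(C)C)C(C)C)C(=O)C(=O)Nc1ccnn1CCC(C)(C)C`, differs from compound 1 by neopentyl in place of hydrogen on a saturated chain carbon bound to an aromatic nitrogen. For the measured compounds named here, no measured step covers a change of this kind, so the move from compound 1 is expected to stay within the scatter: a 1.1-fold lower number from compound 1 to compound 3 (0.05 log units; within the scatter). Compound 3 is therefore estimated at 1500 nM, between 400 nM and 6000 nM.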

Compound 3, half-maximal inhibitory concentration: 1600 nM
Estimate against measurement, compound 3: 1.1-fold (0.03 log units) below, and the stated range covers the measured number.
By their numbers in this assay, from the lowest: compound 2; then compounds 3 and 1 (each within the scatter of the next).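

In this assay, neopentyl in place of hydrogen on a saturated chain carbon bound to an aromatic nitrogen gives a 1.1-fold lower number from compound 1 to compound 3 (0.03 log units; within the scatter), so the change from methyl to 3,3-dimethylbutyl stays within the scatter. Among the compounds shown here, the earlier compounds varied only the ring isomer, and this is the first reading of a change in the group on that nitrogen. No available evidence bears on this result.

Going by these compounds, it remains open whether the same extension behaves alike on the 1-methyl-1H-pyrazol-3-yl isomer, compound 2. Also open, on these data alone, is how an amine or a carboxylic acid at the end of this chain would read.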